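The source may report more compounds than this note shows. Statements on the series, on what has been measured and on what is new or still open speak of the compounds shown alone.

Of the compounds shown here, three sharing one core have been measured in a functional assay on HepG2 cells (Homo sapiens) for cytotoxicity, read by MTT assay, with a stated time of 48 h; a higher number here means a weaker inhibitor, a lower number a stronger inhibitor. Compound 1 `O=C(Nc1ccc(S(=O)(=O)N2CCOCC2)cc1)C1C(C(=O)O)[C@H]2CC[C@@H]1O2` gives 19300 nM. Compound 2 `O=C(Nc1ccc(S(=O)(=O)NC2CCCC2)cc1)C1C(C(=O)O)[C@H]2CC[C@@H]1O2` gives 22300 nM, and compound 3 `CCN1CCN(S(=O)(=O)c2ccc(NC(=O)C3C(C(=O)O)[C@H]4CC[C@@H]3O4)cc2)CC1` gives 20200 nM. The three numbers lie close together: the step of a 1.2-fold higher number from compound 1 to compound 2 (0.06 log units; within the scatter) and the step of a 1.0-fold higher number from compound 1 to compound 3 (0.02 log units; within the scatter) both stay within the scatter, as does a 1.1-fold lower number from compound 2 to compound 3 (0.04 log units; within the scatter), so compound 1 is not set apart from either companion.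

Compound 4 `O=C(Nc1ccc(S(=O)(=O)NC2CCCCC2)cc1)C1C(C(=O)O)[C@H]2CC[C@@H]1O2` is not yet measured in this assay. It differs from compound 1 in one place: cyclohexylamino in place of morpholin-4-yl on a sulfonyl sulfur. The step that bears most directly on this change is a 1.2-fold higher number from compound 1 to compound 2 (0.06 log units; within the scatter), where a cyclopentylamino group also took the place of morpholin-4-yl on the sulfonyl sulfur without moving the number beyond the scatter; the steps involving compound 3 point the same way. Compound 4 is therefore expected to show no step beyond the scatter, with a 1.1-fold higher number from compound 1 to compound 4 (0.04 log units; within the scatter) as the expected change. The estimate for compound 4 in this assay is 21000 nM, within a range of 12000 nM to 38000 nM.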

Compound 4, half-maximal inhibitory concentration in the HepG2 assay: 22500 nM
The estimate for compound 4 lay 1.1-fold (0.03 log units) below the measured number; the measured number falls inside the stated range.
By their numbers in the HepG2 assay, from the lowest: compounds 1, 3, 2 and 4 (each within the scatter of the next).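

In the HepG2 assay, cyclohexylamino on the sulfonyl sulfur leaves compound 4 among the others: a 1.2-fold higher number from compound 1 to compound 4 (0.07 log units; within the scatter), a 1.1-fold higher number from compound 3 to compound 4 (0.05 log units; within the scatter) and a 1.0-fold higher number from compound 2 to compound 4 (0.00 log units; within the scatter), the last being a change of cyclopentyl to cyclohexyl on the sulfonamide nitrogen alone. In a physicochemical assay for lipophilicity (on this read-out higher numbers stand for higher lipophilicity and lower numbers for lower lipophilicity), compound 1 gives 0.4 and compound 4 gives 0.2, two values within the scatter of each other, so this exchange moves neither read-out beyond the scatter. Nothing available explains why these numbers stay together.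

The compounds shown leave open whether an open-chain group such as diethylamino, or an aromatic one such as phenylamino, on the sulfonyl sulfur would move the number in the HepG2 assay beyond the scatter. They also leave open what a methyl ester in place of the carboxylic acid would do.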